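A Second Fluoro on the Phenyl: Compound 3 to Compound 4

The source may hold more compounds than are shown below. What is called first, only, known or untested is meant among the compounds shown, and "the series" means these compounds.

Compound 1, `Cc1cc(=O)n(-c2ccccc2C(F)(F)F)nc1C(=O)Nc1ccc(Oc2ncnc3sccc23)c(F)c1`: in a functional assay on MCF7 cells (Homo sapiens) for cytotoxicity, read by MTT assay, with a stated time of 72 h (on this read-out lower numbers stand for stronger inhibition and higher numbers for weaker inhibition), compound 1 gives 13800 nM.
Compound 2, `Cc1cc(=O)n(-c2ccc(Br)cc2F)nc1C(=O)Nc1ccc(Oc2ncnc3sccc23)c(F)c1`: in this assay compound 2 gives 13300 nM.
Compound 3, `Cc1cc(=O)n(-c2ccc(F)cc2)nc1C(=O)Nc1ccc(Oc2ncnc3sccc23)c(F)c1`: in this assay compound 3 gives 12300 nM.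

All three compounds share the same core and differ only in the aryl group carried on an aromatic nitrogen. Compound 3 has the lowest number of the three, but the steps to its neighbours, a 1.1-fold lower number from compound 2 to compound 3 (0.03 log units; within the scatter) and a 1.1-fold lower number from compound 1 to compound 3 (0.05 log units; within the scatter), both lie within the scatter, so the three values cannot be told apart.

Compound 4, `Cc1cc(=O)n(-c2ccc(F)c(F)c2)nc1C(=O)Nc1ccc(Oc2ncnc3sccc23)c(F)c1`, is the next member. Relative to compound 3 the change is fluoro in place of hydrogen on an aromatic carbon.

Every step measured so far concerns this same aryl group. a 1.0-fold lower number from compound 1 to compound 2 (0.02 log units; within the scatter), a 1.1-fold lower number from compound 1 to compound 3 (0.05 log units; within the scatter) and a 1.1-fold lower number from compound 2 to compound 3 (0.03 log units; within the scatter) show that swapping one substituted phenyl for another, with different halogens in different positions, left the number essentially unchanged. Adding one more fluoro is a smaller change than any of those, so no step beyond the scatter is expected in this assay.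

Compound 4 is therefore estimated at 12500 nM, within a range of 6500 nM to 25000 nM, which corresponds to an expected step of a 1.0-fold higher number from compound 3 to compound 4 (0.01 log units; within the scatter).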

Compound 4, half-maximal inhibitory concentration: 20600 nM
For compound 4 the middle estimate is 1.6-fold (0.22 log units) below the measured one, within the range that was stated.
By their numbers in this assay, from the lowest: compounds 3, 2, 1 and 4 (each within the scatter of the next).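

A fluoro group can sit on the phenyl ring ortho to a fluoro group and meta to a large group, a place where none of the earlier aryl groups carried anything, and in this assay the result is a 1.7-fold higher number from compound 3 to compound 4 (0.22 log units; within the scatter) for this one added atom. The whole 3,4-difluorophenyl group likewise stays level with the other two aryl groups, with a 1.5-fold higher number from compound 2 to compound 4 (0.19 log units; within the scatter) and a 1.5-fold higher number from compound 1 to compound 4 (0.17 log units; within the scatter), so the four compounds still cannot be told apart and the substituents tried on this ring so far have produced no step beyond the scatter. Nothing measured here accounts for the size of these steps.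

As far as these compounds go, all four aryl groups carry only halogens or trifluoromethyl, so it remains open whether an amine, a carboxylic acid or a longer chain at this same place would also stay within the scatter. Also open, from the compounds shown here alone, is whether a change away from this aryl group, on the shared core, would give a step beyond the scatter in this assay at all.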